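This account rests on a few compounds, and the source may have more. Where it says the series, first, only, none or still open, it means among the compounds named here.

Of the compounds shown here, two of a shared core have been measured in an assay on cells for agonist activity at ecdysone receptor (Bombyx mori), read by a luciferase reporter, with a stated time of 24 h; on this read-out lower numbers stand for an effect already at smaller amounts and higher numbers for an effect only at larger amounts of compound. Compound 1 `COc1ccccc1C(=O)N(NC(=O)c1ccccc1)C(C)(C)C` gives 525 nM in this assay. Compound 2 `CC(C)(C)N(NC(=O)c1ccccc1Cl)C(=O)c1ccccc1Cl` gives 331 nM in this assay, the lower of the two numbers, though compound 1 sits close enough that the two values fall within the scatter of each other, so no order between them can be claimed.

Compound 3 `Cc1ccccc1C(=O)NN(C(=O)c1ccccc1Cl)C(C)(C)C` has not yet been measured. It differs from compound 2 by methyl in place of chloro on an aromatic carbon, on an aromatic carbon of a six-membered aromatic ring of carbon only, ortho to a large group. Among the measured compounds shown here, no measured pair in this set isolates this change, so the expectation rests on the structural change alone. The step of a 1.3-fold higher number from compound 2 to compound 3 (0.10 log units; within the scatter) is expected to be small, at most modest in either direction and likely not beyond the scatter. Compound 3 is estimated at 420 nM in this assay, with a range from 150 nM to 1200 nM.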

Compound 3, half-maximal effective concentration: 72.4 nM
For compound 3 the middle estimate is 5.8-fold (0.76 log units) above the measured one; measured number outside the range, below it.
By their numbers in this assay, from the lowest: compound 3; then compounds 2 and 1 (each within the scatter of the next).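

Among the compounds shown here, the swap of chloro for methyl on this aromatic carbon gives a 4.6-fold lower number from compound 2 to compound 3 (0.66 log units; beyond the scatter) in this assay and is the first step in the set to lie beyond the scatter. This position therefore responds to the exchange of a single heavy atom, although neither group adds a ring, a hydrogen-bond donor or acceptor, or a net charge. The compounds shown offer no measurement that would explain the step.

From the compounds shown here alone, it remains open whether the lower number is specific to methyl or would also appear with fluoro, ethyl, or an amine at this place. It is also unknown whether the same exchange would give a step of similar size in a compound that differs elsewhere on the shared core.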